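Swapping an amine side chain for an ether

The source may report more compounds than this note shows. Statements on the series, on what has been measured and on what is new or still open speak of the compounds shown alone.

In a functional assay on RS4-11 cells (Homo sapiens) for inhibition, read by CCK-8 assay, with a stated time of 72 h (a higher number here means a weaker inhibitor, a lower number a stronger inhibitor), compound 2 (`CN1CCC(CNc2ccc(S(=O)(=O)NC(=O)c3ccc(N4CCN(CC5=C(c6ccc(C(F)(F)F)cc6)CC(C)(C)CC5)CC4)cc3Oc3cnc4[nH]ccc4c3)cc2[N+](=O)[O-])C1`) gives 8.3 nM and compound 3 (`CC(C)C(=O)N1CCC(CNc2ccc(S(=O)(=O)NC(=O)c3ccc(N4CCN(CC5=C(c6ccc(C(F)(F)F)cc6)CC(C)(C)CC5)CC4)cc3Oc3cnc4[nH]ccc4c3)cc2[N+](=O)[O-])CC1`) gives 5.3 nM as two values within the scatter of each other. Compound 1 (`CC1(C)CCC(CN2CCN(c3ccc(C(=O)NS(=O)(=O)c4ccc(NCC5CCOCC5)c([N+](=O)[O-])c4)c(Oc4cnc5[nH]ccc5c4)c3)CC2)=C(c2cccc(C(F)(F)F)c2)C1`) gives 63 nM as a clearly higher number than compound 2 shows.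

Compound 4 (`CC1(C)CCC(CN2CCN(c3ccc(C(=O)NS(=O)(=O)c4ccc(OC5CCOCC5)c([N+](=O)[O-])c4)c(Oc4cnc5[nH]ccc5c4)c3)CC2)=C(c2ccc(C(F)(F)F)cc2)C1`) departs from compound 2 in one place, described as (oxan-4-yl)oxy in place of ((1-methylpyrrolidin-3-yl)methyl)amino on an aromatic carbon here. In words, (oxan-4-yl)oxy stands in place of ((1-methylpyrrolidin-3-yl)methyl)amino on an aromatic carbon, ortho to a nitro group.

Within the data shown here, the only measured step at this place is a 1.6-fold lower number from compound 2 to compound 3 (0.19 log units; within the scatter) and it kept the nitrogen on the aromatic ring while exchanging the ring further out. Among the measured compounds shown here, no measured step replaces that nitrogen with oxygen, so the evidence is thin. The only hint of direction is compound 1 with 63 nM as it also carries an oxan-4-yl group, yet it differs from compound 2 in more than one place.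

A modest move toward a higher number in this assay is therefore expected, with wide uncertainty. The estimated move is a 2.4-fold higher number from compound 2 to compound 4 (0.38 log units; beyond the scatter) and it could still prove smaller. Compound 4 is estimated at 20 nM (expected range from 5 nM to 80 nM).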

Compound 4, half-maximal inhibitory concentration: 375 nM
Compound 4: middle estimate off by 19-fold (1.27 log units), on the low side; measured number outside the range, above it.
By their numbers in this assay, from the lowest: compounds 3 and 2 (each within the scatter of the next); then compound 1; then compound 4.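

In this assay, the exchange of ((1-methylpyrrolidin-3-yl)methyl)amino for (oxan-4-yl)oxy gives a 45-fold higher number from compound 2 to compound 4 (1.65 log units; beyond the scatter), so this place on the aromatic ring, ortho to a nitro group, can strongly affect the read-out. The earlier step, a 1.6-fold lower number from compound 2 to compound 3 (0.19 log units; within the scatter), kept the nitrogen on the aromatic ring, changed only the part further out and stayed within the scatter, so it gave no sign of a change this large. The new step changes several things at once: nitrogen gives way to oxygen at the aromatic carbon, a five-membered ring gives way to a six-membered ring, and 1 hydrogen-bond donor gives way to 0 hydrogen-bond donors.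

These compounds leave open which of those differences accounts for the higher number. An oxan-4-ylamino group, or a (1-methylpyrrolidin-3-yl)methoxy group, would separate the effect of the linking atom from that of the ring, since each would change only one of the two relative to compound 2 or compound 4. No measurement here gives a reason for the size of this step.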